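Carbamate in place of an aryloxypropyl ether on a shared core

The source may report more compounds than this note shows. Statements on the series, on what has been measured and on what is new or still open speak of the compounds shown alone.

Compound 2 `CC(C)=CCC1Cc2c(OCCCOc3ccc(Cl)cc3)cc(=O)n(CCCO)c2CC1(C)C` and compound 1 `CC(C)=CCOc1cc(=O)n(CCCO)c2c1CC(CC=C(C)C)C(C)(C)C2` share a core and differ in one place. In a functional assay on PANC-1 cells (Homo sapiens) for inhibition, read by MTT assay, with a stated time of 24 h, tested at 10 uM (a lower number here means less inhibition, a higher number more inhibition at the concentration tested (going by the name of the read-out)), compound 1 gives 7.5%, and compound 2 gives 0%. Among the measured compounds shown here, the one step between them, a number 7.5 percentage points lower from compound 1 to compound 2 (within the scatter), is within the scatter, so the two numbers cannot be told apart; compound 2 merely holds the lowest of the two numbers measured so far, with compound 1 the nearest to it.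

Compound 3 `CC(C)=CCC1Cc2c(OC(=O)Nc3ccc(F)cc3F)cc(=O)n(CCCO)c2CC1(C)C` is not yet measured. It differs from compound 2 in a single place: (2,4-difluorophenyl)carbamoyl in place of 3-(4-chlorophenoxy)propyl on an oxygen on an aromatic ring. For the measured compounds named here, no measured step bears on this change, since the only step known, from compound 1 to compound 2, exchanges one chain for another on the same oxygen and stays within the scatter. Both measured compounds sit near the bottom of the read-out, and nothing in the data points away from it. Compound 3 is therefore expected to give 6%, within 0% to 25%, an expected step of a number 6 percentage points higher from compound 2 to compound 3 (within the scatter) that would not rise beyond the scatter.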

Compound 3, a percentage reported as inhibition, at one concentration (the size of the read-out at that concentration, not a potency): 0%
For compound 3 the middle estimate is 6 percentage points above the measured one; measured number inside the range.
By their numbers in this assay, from the lowest: compounds 2, 3 and 1 (each within the scatter of the next).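

In this assay, the (2,4-difluorophenyl)carbamoyl group on the oxygen on the aromatic ring replaces 3-(4-chlorophenoxy)propyl with no change at the digits printed from compound 2 to compound 3 (within the scatter), which shows that a carbamoyl link carrying a nitrogen and a hydrogen-bond donor reads the same here as the ether-linked aryl chain. Set against the 3-methylbut-2-en-1-yl group, the same carbamoyl gives a number 7.5 percentage points lower from compound 1 to compound 3 (within the scatter), so the three groups now seen on this oxygen, one without a ring and two with an aromatic ring, cannot be told apart, and compound 3 stays at 0%. Nothing available explains why these exchanges leave the number within the scatter.

The compounds shown leave open whether any group on this oxygen can move the number beyond the scatter, for instance a chain ending in a tertiary amine or a carboxylic acid. They also leave open whether the carbamoyl would read the same on a core changed elsewhere, as all three compounds share a single core and a single tested concentration.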